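Lengthening the Ester Chain: A Prediction for Compound 4

The source may hold more compounds than are shown below. What is called first, only, known or untested is meant among the compounds shown, and "the series" means these compounds.

Compound 2 `COC(=O)/C=C/c1ccc2c(c1)C(=O)C(=O)N2Cc1ccc(OC)cc1` gives 30 nM in a functional assay on HepG2 cells (Homo sapiens) for cytotoxicity, read by MTT assay, with a stated time of 48 h (a higher number here means a weaker inhibitor, a lower number a stronger inhibitor), the lowest of the three numbers recorded. Compound 1 `COC(=O)/C=C/c1ccc2c(c1)C(=O)C(=O)N2Cc1ccc(C)cc1` gives 40 nM in this assay, and compound 3 `COC(=O)/C=C/c1ccc2c(c1)C(=O)C(=O)N2Cc1ccc(C(F)(F)F)cc1` gives 70 nM. The steps seen so far are a 1.3-fold lower number from compound 1 to compound 2 (0.12 log units; within the scatter), a 1.8-fold higher number from compound 1 to compound 3 (0.24 log units; within the scatter) and a 2.3-fold higher number from compound 2 to compound 3 (0.37 log units; beyond the scatter), all of them changes on an aromatic carbon.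

Compound 4 `CCOC(=O)/C=C/c1ccc2c(c1)C(=O)C(=O)N2Cc1ccc(OC)cc1` differs from compound 2 at another place: methyl in place of hydrogen on a saturated chain carbon bound to an oxygen next to a carbonyl group. Among the compounds with values here, no measured step touches this position, so the measured steps give no direct guide; they only show that the series as a whole moves within a narrow band. The step expected is no change at the digits printed from compound 2 to compound 4 (within the scatter), which amounts to nothing beyond the scatter. Compound 4 is therefore estimated to give about 30 nM in this assay, between 15 nM and 60 nM.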

Compound 4, half-maximal inhibitory concentration: 90 nM
Compound 4: middle estimate off by 3.0-fold (0.48 log units), on the low side, outside the stated range (above it).
By their numbers in this assay, from the lowest: compounds 2, 1, 3 and 4 (each within the scatter of the next, the first and the last beyond it).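

In this assay the change from methoxycarbonyl to ethoxycarbonyl gives a 3.0-fold higher number from compound 2 to compound 4 (0.48 log units; beyond the scatter) and so shows that this position responds to a single added methyl, which the changes on the aromatic carbon could not reveal. Within the data shown here, the move is toward a weaker inhibitor, and it is the largest single step seen so far. Nothing available explains this result.

On these data alone, whether a longer chain or a carboxylic acid at this position would move the number further stays open. So does whether the same ethoxycarbonyl change would give a similar step with methyl or trifluoromethyl on the aromatic carbon.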